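Cyclopropyl in place of 4-methylphenyl: compound 4

A few compounds are considered here, and "the series" means these few. Any claim that something is new, unique, unknown or untested is made for them only; others in the source may bear on it.

Compound 3 `Cc1ccc(-c2nnn(CC(=O)Nc3cc(C)nn3C3CCCCC3)n2)cc1` gives 111 nM in an assay on HEK293 cells for activation of Kir3.1/Kir3.2 (Homo sapiens), read by thallium flux; a lower number here means that less compound is needed, a higher number that more compound is needed for the effect. Compound 1 `Cc1cc(NC(=O)Cn2nnc(-c3ccccc3)n2)n(C2CCCCC2)n1` gives 96 nM and compound 2 `Cc1cc(NC(=O)Cn2nnc(-c3ccc(F)cc3)n2)n(C2CCCCC2)n1` gives 180 nM; compound 3 lies within the scatter of both, as the steps of a 1.2-fold higher number from compound 1 to compound 3 (0.06 log units; within the scatter) and a 1.6-fold lower number from compound 2 to compound 3 (0.21 log units; within the scatter) show. Compound 4 `Cc1cc(NC(=O)Cn2nnc(C3CC3)n2)n(C2CCCCC2)n1` differs from compound 3 by cyclopropyl in place of 4-methylphenyl on an aromatic carbon. Among the compounds with values here, no measured step bears directly on this change: every step so far, including a 1.9-fold higher number from compound 1 to compound 2 (0.27 log units; within the scatter), alters only a substituent on the six-membered aromatic ring and stays within the scatter, whereas here that ring itself leaves. The expected step is therefore uncertain and is taken as a 3.6-fold higher number from compound 3 to compound 4 (0.56 log units; beyond the scatter), toward a higher number. Compound 4 is estimated at 400 nM, with a range from 100 nM to 1600 nM.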

Compound 4, half-maximal effective concentration: > 3000 nM
Compound 4: only a limit was reported; the forecaster's own chance of this, stated with the estimate: 15%; at least 7.5-fold (0.87 log units) between middle value and limit.
By their numbers in this assay, from the lowest: compounds 1, 3 and 2 (each within the scatter of the next). At a limit, above all of these: compound 4.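

At this position, on the aromatic carbon of the five-membered aromatic ring with 4 nitrogen, the earlier changes to the phenyl substituent all stayed within the scatter, but the six-membered aromatic ring itself cannot be exchanged for cyclopropyl without a large loss. The steps are an at least 27-fold higher number from compound 3 to compound 4 (1.43 log units; beyond the scatter), an at least 16-fold higher number from compound 2 to compound 4 (1.22 log units; beyond the scatter) and an at least 31-fold higher number from compound 1 to compound 4 (1.49 log units; beyond the scatter). The value of compound 4 in this assay is a limit, so these steps have no upper end: the limit of > 3000 nM in this assay, at which 1 of the 4 values shown sits.

On these data alone, whether the aromatic ring or the larger heavy-atom count matters here stays open. A tert-butyl group or a pyridyl ring at this position would help separate the two.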